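From Methyl to Isopropyl on a Shared Core

This account rests on a few compounds, and the source may have more. Where it says the series, first, only, none or still open, it means among the compounds named here.

Of the compounds shown here, three have so far been tested in a functional assay on the whole organism (strain Sprague-Dawley) for inhibition, with Rattus norvegicus as the target; a lower number here means that less compound is needed, a higher number that more compound is needed for the effect. Compound 1 `CCCCc1ccc2ncc(-c3nn[nH]n3)cc2c1` gives 5 mg/kg, and compound 3 `COc1ccc2c(=O)c(-c3nn[nH]n3)c[nH]c2c1` gives 10 mg/kg. Compound 2 `Cc1cccc2c(=O)c(-c3nn[nH]n3)c[nH]c12` returns only a limit, > 5 mg/kg, so no single number fixes its dose. the limit of > 5 mg/kg in this assay, at which 1 of the 3 values shown sits, is all that is known about where compound 2 stands, and it leaves open whether compound 2 sits close to the other two or needs far more.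

Compound 4 `CC(C)c1cccc2c(=O)c(-c3nn[nH]n3)c[nH]c12` has not yet been measured. It differs from compound 2 in one place: isopropyl in place of methyl on an aromatic carbon. For the measured compounds named here, no exchange of this kind appears among the measured compounds, and compound 2 itself is known only as a limit, so there is no measured step against which the change from methyl to isopropyl can be judged. The estimate for compound 4 therefore rests on the spread of the measured values. Compound 4 is expected to need about 10 mg/kg, within 3 mg/kg to 30 mg/kg, and the step that the limit leaves unreadable from compound 2 to compound 4 is expected to be small or none beyond the scatter, with a real chance that this assay again reports only a limit.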

Compound 4, minimum effective dose: 1.25 mg/kg
The estimate for compound 4 lay 8.0-fold (0.90 log units) above the measured number, and the stated range ends above it.
By their numbers in this assay, from the lowest: compound 4; then compounds 1 and 3 (each within the scatter of the next).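

The earlier compounds shown here offered no measured step at this position, and now there is one: in this assay, the exchange of methyl for isopropyl gives an at least 4.0-fold lower number from compound 2 to compound 4 (0.60 log units; beyond the scatter). This shows that the group on this aromatic carbon can change the dose needed, and that isopropyl here needs less compound than methyl. The true size of the step remains unknown, as compound 2 is known only as a limit: the limit of > 5 mg/kg in this assay, at which 1 of the 4 values shown sits.

A single step cannot separate the effect of a longer chain from that of branching, and an ethyl or a tert-butyl group on the same carbon would help to tell these apart. As far as these compounds go, it also remains open whether isopropyl would have a similar effect elsewhere on the shared core, or whether an amine or a carboxylic acid would be tolerated at this position.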